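Cyano for bromo on the diaryl core series

This account rests on a few compounds, and the source may have more. Where it says the series, first, only, none or still open, it means among the compounds named here.

Compound 1 `Brc1ccc(-c2ncc(OCC3CCNCC3)nc2-c2ccc(Br)cc2)cc1`: 5700 nM in an assay on isolated protein for inhibition of histone acetyltransferase p300 (Homo sapiens), read by scintillation counting, with stated times of 10 min and 30 min; on this read-out higher numbers stand for weaker inhibition and lower numbers for stronger inhibition
Compound 2 `Brc1ccc(-c2ncc(OCC3CCNC3)nc2-c2ccc(Br)cc2)cc1`: > 10000 nM, a limit of this assay
Compound 3 `Ic1ccc(-c2ncc(OCC3CCNCC3)nc2-c2ccc(I)cc2)cc1`: 7800 nM in this assay

Compound 1 and compound 3 give numbers within the scatter of each other in this assay, so neither is placed ahead of the other. Compound 2 yields only a limit, (the limit of > 10000 nM in this assay, at which 1 of the 3 values shown sits). For the measured compounds named here, the one measured step, an at least 1.7-fold higher number from compound 1 to compound 2 (0.24 log units; that floor lies within the scatter), alters the amine ring and not the aryl groups, so it does not bear on the change now in question.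

Compound 4 `N#Cc1ccc(-c2nc(OCC3CCNCC3)cnc2-c2ccc(Br)cc2)cc1` differs from compound 1 by cyano in place of bromo on an aromatic carbon. Going by the values given here, no measured step swaps a halogen for a nitrile; the closest comparison, bromo against iodo in compound 1 and compound 3, shows no shift beyond the scatter. Compound 4 is therefore expected to show a step of a 1.1-fold higher number from compound 1 to compound 4 (0.06 log units; within the scatter). Compound 4 is estimated at 6500 nM, with a range of 2500 nM to 15000 nM.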

Compound 4, half-maximal inhibitory concentration: > 10000 nM
Compound 4 gave a limit, no number; the forecaster's own chance of this, stated with the estimate: 30%; middle value at least 1.5-fold (0.18 log units) from the limit.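

Compound 4 gives > 10000 nM in this assay, a limit and not a number. The change therefore reads only as an at least 1.7-fold higher number from compound 1 to compound 4 (0.24 log units; that floor lies within the scatter), so a loss beyond the scatter is not established, although bromo and iodo both gave numbers. Among the aryl substituents shown, only cyano reaches the limit, which the change of amine ring also reached: the limit of > 10000 nM in this assay, at which 2 of the 4 values shown sit.

As far as these compounds go, the true size of the step stays open. So does whether an amine or a carboxylic acid in place of bromo at this position would give a number in this assay.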